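Adding Methyls to the Amine of Compound 2

The source may report more compounds than this note shows. Statements on the series, on what has been measured and on what is new or still open speak of the compounds shown alone.

Compound 1 `CC(C)NCCCOc1cccc2ccccc12` gives 7660 nM in a functional assay for agonist activity at 5-hydroxytryptamine receptor 1B (Homo sapiens); a higher number here means a weaker inhibitor, a lower number a stronger inhibitor.
Compound 2 `NCCCOc1cccc2ccccc12` gives 290 nM.
Compound 3 `CNCCCOc1ccccc1` gives 3450 nM.

Compound 2 stands lowest of the three in this assay; compound 3 is nearest and compound 1 furthest, both beyond the scatter. Compound 4 `CN(C)CCCCOc1cccc2ccccc12` has not yet been measured. It differs from compound 2 by (dimethylamino)methyl in place of amino on a saturated chain carbon, three bonds along the chain from an oxygen on an aromatic ring. For the measured compounds named here, the one measured step that bears on this is a 26-fold lower number from compound 1 to compound 2 (1.42 log units; beyond the scatter), a large drop on taking an alkyl group off the amine nitrogen. Compound 4 goes the other way, putting two methyls on that nitrogen and one more carbon in the chain. Compound 3, which carries a methyl on its nitrogen, also sits well above compound 2, though on a different core. An upward step beyond the scatter is therefore expected, a 10-fold higher number from compound 2 to compound 4 (1.01 log units; beyond the scatter). Compound 4 is expected near 3000 nM, within 600 nM to 15000 nM.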

Compound 4, inhibition constant: 470 nM
Compound 4: middle estimate off by 6.4-fold (0.81 log units), on the high side, and the stated range ends above it.
By their numbers in this assay, from the lowest: compounds 2 and 4 (each within the scatter of the next); then compound 3; then compound 1.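

In this assay, (dimethylamino)methyl in place of amino at this chain carbon gives a 1.6-fold higher number from compound 2 to compound 4 (0.21 log units; within the scatter) and so leaves the number within the scatter despite the added carbons. Set against isopropylamino, the same position gives a 16-fold lower number from compound 1 to compound 4 (1.21 log units; beyond the scatter) as a large step, so carrying alkyl groups on the amine nitrogen does not by itself bring the high number of compound 1. Nothing available explains this difference.

On these data alone, compound 4 changes the nitrogen's substituents and the chain length together, so the share of each stays open. As far as these compounds go, how a diethylamino group would read on this chain also remains open.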